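The source may hold more compounds than are shown below. What is called first, only, known or untested is meant among the compounds shown, and "the series" means these compounds.

Compound 2 `CCS(=O)(=O)CCCCC12CCC(c3nnc(-c4ccccc4C(F)(F)F)n3C)(CC1)CC2` and compound 1 `Cn1c(-c2ccccc2C(F)(F)F)nnc1C12CCC(CCS(=O)(=O)C(C)(C)C)(CC1)CC2` share the same core and differ only in the side chain on the saturated ring carbon. In an assay on CHO-K1 cells for inhibition of 11-beta-hydroxysteroid dehydrogenase type 2 (Mus musculus), read by scintillation proximity assay (a higher number here means a weaker inhibitor, a lower number a stronger inhibitor), compound 1 gives > 4000 nM, which is a limit of the assay and not a number. In this assay compound 2 likewise gives > 4000 nM, again only a limit. The step that the two limits leave unreadable from compound 1 to compound 2 therefore cannot be read, because of the limit of > 4000 nM in this assay, at which 2 of the 2 values shown sit. Compound 3 `CCCCCC12CCC(c3nnc(-c4ccccc4C(F)(F)F)n3C)(CC1)CC2` is the next variant: methyl in place of ethylsulfonyl on a saturated chain carbon, four bonds along the chain from a saturated ring carbon, so the sulfone is gone and only a plain saturated chain remains. Within the data shown here, no measured step bears on this change with a readable size, since the single step available is unreadable. Compound 3 is therefore expected to sit at or beyond the limit region, estimated at 6000 nM with a range from 1500 nM to 30000 nM. That estimate means an expected step that the limit leaves unreadable from compound 2 to compound 3, not beyond the scatter in either direction.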

Compound 3, half-maximal inhibitory concentration: > 4000 nM
Compound 3: a limit, no number; the forecaster's own chance of this, stated with the estimate: 75%; the middle value does not contradict the limit.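

No step can be read between compound 1, compound 2 and compound 3 in this assay, because each gives only a limit and not a number: the limit of > 4000 nM in this assay, at which 3 of the 3 values shown sit. The compounds shown leave open how strongly each one inhibits, and whether methyl in place of ethylsulfonyl changes inhibition at all.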